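The compounds below may be only part of what the source reports. "The series", "measured", "known", "first", "only" and "open" are said of these compounds alone.

Compound 1 `O=C(CCl)NC(=O)Nc1cccc(OC2CCCCC2)c1`: 2700 nM
Compound 2 `O=C(CCl)NC(=O)Nc1cccc(OC2CCCCCC2)c1`: 4200 nM

In a functional assay on M21 cells (Homo sapiens) for inhibition, read by sulforhodamine B assay, with a stated time of 48 h (on this read-out lower numbers stand for stronger inhibition of growth and higher numbers for weaker inhibition of growth), compound 2 gives 4200 nM, which lies within the scatter of compound 1, as a 1.6-fold higher number from compound 1 to compound 2 (0.19 log units; within the scatter) shows. Compound 3 `O=C(CCl)NC(=O)Nc1cccc(OCc2ccccc2)c1` has benzyl in place of cycloheptyl on an oxygen on an aromatic ring. For the measured compounds named here, the one measured step bearing on this is a 1.6-fold higher number from compound 1 to compound 2 (0.19 log units; within the scatter), a swap between non-aromatic rings. Going by the values given here, no measured compound carries benzyl there, so the guide is loose. The expected change, a 1.2-fold lower number from compound 2 to compound 3 (0.08 log units; within the scatter), stays within the scatter. Compound 3 is estimated at 3500 nM, with an expected range of 1500 nM to 8000 nM.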

Compound 3, concentration for 50% growth inhibition: 4500 nM
Beside the measured number, compound 3's estimate is 1.3-fold (0.11 log units) below it, and the stated range covers the measured number.
By their numbers in this assay, from the lowest: compounds 1, 2 and 3 (each within the scatter of the next).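

In this assay, the step of a 1.1-fold higher number from compound 2 to compound 3 (0.03 log units; within the scatter) and the step of a 1.7-fold higher number from compound 1 to compound 3 (0.22 log units; within the scatter) both stay within the scatter. On an oxygen on an aromatic ring, then, an aromatic ring carried on benzyl reads like the two non-aromatic rings, which the earlier pair alone could not show. Nothing available explains this result. Still open, going by these compounds, is whether a small group such as methyl, or a longer chain ending in an amine or a carboxylic acid, would move the number beyond the scatter.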